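From Ethoxy to Phenyl on a Carbonyl Carbon

The source may hold more compounds than are shown below. What is called first, only, known or untested is meant among the compounds shown, and "the series" means these compounds.

In a functional assay on Hs 683 cells (Homo sapiens) for cytotoxicity, read by MTT assay, with a stated time of 72 h (a lower number here means a stronger inhibitor, a higher number a weaker inhibitor), compound 1 `CSc1nc(Cl)c(C(=O)c2ccccc2)s1` gives > 100000 nM, which is a limit and not a number. Among the measured compounds shown here, compound 2 `CCOC(=O)c1sc(N2CCCC2)nc1Cl` gives 54000 nM, the only true number available so far. Compound 3 `O=C(c1ccccc1)c1sc(N2CCCC2)nc1Cl` differs from compound 2 in one place: phenyl in place of ethoxy on a carbonyl carbon. For the measured compounds named here, no measured step speaks to this change, so only a modest shift towards stronger inhibition, close to the scatter, is expected in this assay. The expected change is a 2.2-fold lower number from compound 2 to compound 3 (0.33 log units; beyond the scatter). For compound 3 the estimated value is 25000 nM, with an expected range from 7000 nM to 100000 nM.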

Compound 3, half-maximal inhibitory concentration: 44000 nM
For compound 3 the middle estimate is 1.8-fold (0.25 log units) below the measured one; low and high end bracket the measured number.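

In this assay, phenyl in place of ethoxy on a carbonyl carbon gives a 1.2-fold lower number from compound 2 to compound 3 (0.09 log units; within the scatter) and so leaves the number without a readable change at this position. With phenyl on the carbonyl carbon in both compounds, pyrrolidin-1-yl in place of methylsulfanyl on an aromatic carbon gives an at least 2.2-fold lower number from compound 1 to compound 3 (0.35 log units; beyond the scatter) and thus a step beyond the scatter. That step is a bound and not an exact size, since the value of compound 1 is a limit: the limit of > 100000 nM in this assay, at which 1 of the 3 values shown sits.

Going by these compounds, whether an amine or a carboxylic acid on the carbonyl carbon would shift the number stays open. So does the effect of a longer chain in place of pyrrolidin-1-yl.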